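Swapping an aromatic ring for a short chain

The source may hold more compounds than are shown below. What is called first, only, known or untested is meant among the compounds shown, and "the series" means these compounds.

Measured compounds:
compound 1 `COC(=O)/C=C/c1cccc(N(Cc2ccc(-c3ccc(OC)cc3)cc2)C(=O)C(C)C)c1` — 97 nM
compound 2 `COC(=O)/C=C/c1cccc(N(Cc2ccc(-c3c(OC)cccc3OC)cc2)C(=O)C2CCCCC2)c1` — 77 nM
compound 3 `COC(=O)/C=C/c1cccc(N(Cc2ccc(-c3c(OC)cccc3OC)cc2)C(=O)C(C)C)c1` — 95 nM

In an assay on isolated protein with Bile acid receptor (Homo sapiens) as the target (a higher number here means that more compound is needed for the effect, a lower number that less compound is needed), the three values sit within the usual scatter of one another, and compound 2 sits at one end of that narrow span. Compound 4 `COC/C=C/c1ccc(CN(C(=O)C2CCCCC2)c2cccc(/C=C/C(=O)OC)c2)cc1` is built from compound 2 by one change: 3-methoxyprop-1-en-1-yl in place of 2,6-dimethoxyphenyl on an aromatic carbon. Among the measured compounds shown here, no measured step covers a swap of this kind. The nearest is a 1.0-fold lower number from compound 1 to compound 3 (0.01 log units; within the scatter), which only shows that altering the substituents on that aromatic ring left this assay unchanged; a 1.2-fold higher number from compound 2 to compound 3 (0.09 log units; within the scatter) concerns a different place. From the compounds shown here alone, removing the ring itself is untested, so a weakening step is expected but with wide uncertainty. Compound 4 is therefore estimated at 250 nM (range 80 nM to 800 nM), a step of a 3.2-fold higher number from compound 2 to compound 4 (0.51 log units; beyond the scatter).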

Compound 4, half-maximal effective concentration: 233 nM
The estimate for compound 4 lay 1.1-fold (0.03 log units) above the measured number; measured number inside the range.
By their numbers in this assay, from the lowest: compounds 2, 3 and 1 (each within the scatter of the next); then compound 4.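

In this assay, among the compounds shown here, the earlier compounds changed only how the methoxy groups sit on the aromatic ring at this position, whereas removing that ring altogether gives a 3.0-fold higher number from compound 2 to compound 4 (0.48 log units; beyond the scatter). So replacing 2,6-dimethoxyphenyl with the open 3-methoxyprop-1-en-1-yl chain does change the number, unlike the substituent change on the ring. No evidence at hand explains this step. From the compounds shown here alone, it remains open how a pyridine ring or a longer chain ending in an amine would behave at this position, and whether the ring itself is what matters.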